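The source may hold more compounds than are shown below. What is called first, only, known or untested is meant among the compounds shown, and "the series" means these compounds.

Measured compounds:
- compound 1, `NC(=S)N1N=C(c2ccc(N3CCCCC3)cc2)CC1c1ccc(Cl)cc1`, 33800 nM
- compound 2, `Clc1ccc(-c2csc(N3N=C(c4ccc(N5CCCCC5)cc4)CC3c3ccc(Cl)cc3)n2)cc1`, 46400 nM
- compound 3, `Clc1ccc(C2CC(c3ccc(N4CCCCC4)cc3)=NN2c2nc(-c3ccc(Br)cc3)cs2)cc1`, 39700 nM

The three compounds share a core and were tested in a functional assay on A549 cells (Homo sapiens) for antiproliferative activity, read by MTT assay, with a stated time of 72 h; a higher number here means a weaker inhibitor, a lower number a stronger inhibitor. Compound 1 gives 33800 nM, compound 2 gives 46400 nM, and compound 3 gives 39700 nM. Compound 3 sits with steps to both other compounds that stay inside the scatter: a 1.2-fold higher number from compound 1 to compound 3 (0.07 log units; within the scatter) and a 1.2-fold lower number from compound 2 to compound 3 (0.07 log units; within the scatter). The larger replacement on the amine nitrogen in the ring, a 1.4-fold higher number from compound 1 to compound 2 (0.14 log units; within the scatter), also did not move the number beyond the scatter.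

Compound 4, `Cc1ccc(-c2csc(N3N=C(c4ccc(N5CCCCC5)cc4)CC3c3ccc(Cl)cc3)n2)cc1`, has not been measured in this assay . It differs from compound 3 by methyl in place of bromo on an aromatic carbon. The step that bears on this change is the halogen swap from compound 2 to compound 3, a 1.2-fold lower number from compound 2 to compound 3 (0.07 log units; within the scatter), which was within the scatter; the other two steps, which alter the same part of the molecule more deeply, were also within the scatter. A change of one heavy atom on that aromatic carbon is therefore expected to leave the number where it is, with no step beyond the scatter in either direction.

Compound 4 is thus estimated at 40000 nM in this assay , with a range from 20000 nM to 80000 nM, which means an expected step of a 1.0-fold higher number from compound 3 to compound 4 (0.00 log units; within the scatter).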

Compound 4, half-maximal inhibitory concentration: > 100000 nM
Compound 4 ended at the assay's limit; the forecaster's own chance of this, stated with the estimate: 10%; middle value at least 2.5-fold (0.39 log units) away from the limit.
By their numbers in this assay, from the lowest: compounds 1, 3 and 2 (each within the scatter of the next). At a limit, above all of these: compound 4.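

Compound 4 gives > 100000 nM in this assay, which is a limit of the assay and not a number, and it is the only such value among the compounds shown: the limit of > 100000 nM in this assay, at which 1 of the 4 values shown sits.

Within the data shown here, on this aromatic carbon, para to a large group, the earlier compounds showed only that chloro and bromo could not be told apart, with a 1.2-fold lower number from compound 2 to compound 3 (0.07 log units; within the scatter), whereas methyl is the first group there to give a step beyond the scatter, with an at least 2.5-fold higher number from compound 3 to compound 4 (0.40 log units; beyond the scatter) and an at least 2.1-fold higher number from compound 2 to compound 4 (0.33 log units; beyond the scatter). The larger group on the amine nitrogen in the ring also reads differently with methyl on it, for an at least 2.9-fold higher number from compound 1 to compound 4 (0.47 log units; beyond the scatter) lies beyond the scatter, while a 1.4-fold higher number from compound 1 to compound 2 (0.14 log units; within the scatter) and a 1.2-fold higher number from compound 1 to compound 3 (0.07 log units; within the scatter) do not.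

From the compounds shown here alone, the true size of these steps stays unknown, as compound 4 has no number beyond its limit. With only chloro, bromo and methyl at this position, the compounds shown leave open whether a fluoro, a methoxy or an amine on that carbon would keep the number of compound 3 or would reach the limit of compound 4.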